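A Methoxy Added to a Nitro-Bearing Sulfonamide

The source may hold more compounds than are shown below. What is called first, only, known or untested is meant among the compounds shown, and "the series" means these compounds.

Compound 1 `Cc1ccc2cccc(NS(=O)(=O)c3ccccc3[N+](=O)[O-])c2n1` was examined in an assay on HUVEC cells for inhibition of transcription factor p65 (Homo sapiens); a higher number here means a larger maximal response, a lower number a smaller maximal response. There compound 1 reaches > 90%, which is a limit of the assay rather than a number. Compound 2 `O=[N+]([O-])c1cc(C(F)(F)F)ccc1S(=O)(=O)Nc1cccc2cccnc12` gives > 90%, likewise a limit. Compound 3 `COc1cc(NS(=O)(=O)c2ccc(C)cc2[N+](=O)[O-])c2ncccc2c1` gives > 90%, again a limit. All three thus stand at the same place: the limit of > 90% in this assay, at which 3 of the 3 values shown sit. Compound 1 therefore sits at the ceiling with the two others, with no number to rank it.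

Compound 4 `COc1ccc(S(=O)(=O)Nc2cccc3ccc(C)nc23)c([N+](=O)[O-])c1` has not been measured. It differs from compound 1 by methoxy in place of hydrogen on an aromatic carbon. Within the data shown here, no step between measured compounds is available. The step expected is a step that the limit leaves unreadable from compound 1 to compound 4, none beyond the scatter, because every measured value sits at the limit of > 90% in this assay, at which 3 of the 3 values shown sit. Compound 4 is accordingly estimated at 95%, within a range from 85% to 100%, most likely reported once more only as a limit.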

Compound 4, largest response reached (reported as efficacy), in percent of the reference or control that the assay uses: 78%
Compound 4: middle estimate off by 17 percentage points, on the high side, outside the stated range (below it).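

In this assay, methoxy in place of hydrogen, on the aromatic carbon meta to a nitro group and para to a large group, gives a number at least 12 percentage points lower from compound 1 to compound 4 (beyond the scatter). Compound 4, at 78%, is the only compound shown with a readable number, so this position is the first to show a change in the maximal response. The true size of the step stays unknown, because compound 1 gives only a limit: the limit of > 90% in this assay, at which 3 of the 4 values shown sit.

On these data alone, whether this drop is specific to methoxy remains open. The compounds shown do not tell how a hydroxyl, an amine or a longer ether chain on the same carbon would read.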